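Aryl variation on the double-bonded carbon: compound 3 to 4

The compounds below may be only part of what the source reports. "The series", "measured", "known", "first", "only" and "open" are said of these compounds alone.

Compound 3 `CN(C)CCn1cnnc1-c1cc(Oc2ccc(NC(=O)N/N=C/c3ccc(F)cc3)cc2F)ccn1` stands at the high end of the three measured numbers: in a functional assay on HT-29 cells (Homo sapiens) for cytotoxicity, read by MTT assay, with a stated time of 72 h (a lower number here means a stronger inhibitor, a higher number a weaker inhibitor), compound 3 gives 1370 nM. Compound 1 `CN(C)CCn1cnnc1-c1cc(Oc2ccc(NC(=O)N/N=C/c3ccc(Cl)cc3Cl)cc2F)ccn1` gives 390 nM, and compound 2 `CN(C)CCn1cnnc1-c1cc(Oc2ccc(NC(=O)N/N=C/c3c(Cl)cccc3Cl)cc2F)ccn1` gives 280 nM. The steps onto compound 3 were a 3.5-fold higher number from compound 1 to compound 3 (0.55 log units; beyond the scatter) and a 4.9-fold higher number from compound 2 to compound 3 (0.69 log units; beyond the scatter), while between the two dichlorophenyl compounds the step was a 1.4-fold lower number from compound 1 to compound 2 (0.14 log units; within the scatter).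

Compound 4 `COc1cc(/C=N/NC(=O)Nc2ccc(Oc3ccnc(-c4nncn4CCN(C)C)c3)c(F)c2)cc(OC)c1OC` differs from compound 3 in one place: 3,4,5-trimethoxyphenyl in place of 4-fluorophenyl on a carbon with a double bond to nitrogen. Within the data shown here, none of the measured steps introduces a 3,4,5-trimethoxyphenyl; the measured steps show only that the 4-fluorophenyl of compound 3 gives a higher number than either dichlorophenyl, so a swap away from 4-fluorophenyl has room to move in either direction, and a modest step is the most that can be read from them. Compound 4 is therefore estimated at 900 nM, with a range from 250 nM to 3500 nM. The expected step is a 1.5-fold lower number from compound 3 to compound 4 (0.18 log units; within the scatter), with wide uncertainty.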

Compound 4, half-maximal inhibitory concentration: 3620 nM
Estimate against measurement, compound 4: 4.0-fold (0.60 log units) below; the whole stated range lies below it.
By their numbers in this assay, from the lowest: compounds 2 and 1 (each within the scatter of the next); then compound 3; then compound 4.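

In this assay, among these compounds, the 3,4,5-trimethoxyphenyl is the first group on the carbon with a double bond to nitrogen to sit above the 4-fluorophenyl, with a 2.6-fold higher number from compound 3 to compound 4 (0.42 log units; beyond the scatter) so the 4-fluorophenyl no longer marks the high end of the series. Among the compounds shown here, the distance from the dichlorophenyl compounds is larger still, with a 13-fold higher number from compound 2 to compound 4 (1.11 log units; beyond the scatter) and a 9.3-fold higher number from compound 1 to compound 4 (0.97 log units; beyond the scatter) giving this position a wider span than the earlier compounds showed. Nothing at hand accounts for this order of the groups.

Open, going by these compounds, is whether the higher number follows from the methoxy groups as such or from their number, which a phenyl carrying a single methoxy group would begin to separate. Also open is how an amine or a carboxylic acid on the same phenyl would place among these four compounds.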